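Three Aryl Groups Measured, a Fluorophenyl Awaits

This account rests on a few compounds, and the source may have more. Where it says the series, first, only, none or still open, it means among the compounds named here.

Three compounds share one core and differ only in the group on an amine nitrogen in a ring. Compound 1 `CCCc1nc(-c2ccccc2)c(CNCCCN2CCN(c3cccc(C)c3)CC2)o1` gives 47.8% in an assay on HEK293 cells for inhibition of Voltage-dependent T-type calcium channel subunit alpha-1G (Homo sapiens), read by fluorescence, tested at 10 uM; on this read-out higher numbers stand for more inhibition at the one concentration tested (going by the name of the read-out) and lower numbers for less inhibition. Compound 2 `CCCc1nc(-c2ccccc2)c(CNCCCN2CCN(c3ccccc3C(F)(F)F)CC2)o1` gives 45% in this assay, and compound 3 `CCCc1nc(-c2ccccc2)c(CNCCCN2CCN(c3ccc(C(F)(F)F)cc3)CC2)o1` gives 51.6%. Compound 3 holds the highest of the three numbers, but every gap stays inside the scatter: a number 3.8 percentage points higher from compound 1 to compound 3 (within the scatter), a number 6.6 percentage points higher from compound 2 to compound 3 (within the scatter) and a number 2.8 percentage points lower from compound 1 to compound 2 (within the scatter). Compound 4 `CCCc1nc(-c2ccccc2)c(CNCCCN2CCN(c3cccc(F)c3)CC2)o1` has not yet been measured. It differs from compound 3 in one place: 3-fluorophenyl in place of 4-(trifluoromethyl)phenyl on an amine nitrogen in a ring. Among the measured compounds shown here, the three measured steps all concern the group on this ring nitrogen, and none of them moved the read-out beyond the scatter, so nothing among the measured compounds points to a step of any size here either. Compound 4 is therefore estimated at 48% in this assay, with a range from 38% to 58%. The expected step of a number 3.6 percentage points lower from compound 3 to compound 4 (within the scatter) is one that stays within the scatter.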

Compound 4, a percentage reported as inhibition, at one concentration (the size of the read-out at that concentration, not a potency): 68.9%
Compound 4: middle estimate off by 20.9 percentage points, on the low side; the whole stated range lies below it.
By their numbers in this assay, from the lowest: compounds 2, 1 and 3 (each within the scatter of the next); then compound 4.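

The group on this ring nitrogen can move the read-out after all: in this assay, 3-fluorophenyl stands clear of both trifluoromethylphenyl groups, with a number 17.3 percentage points higher from compound 3 to compound 4 (beyond the scatter) and a number 23.9 percentage points higher from compound 2 to compound 4 (beyond the scatter). The change need not involve a whole new substituent pattern, since fluoro in place of methyl on an aromatic carbon gives a number 21.1 percentage points higher from compound 1 to compound 4 (beyond the scatter). The compounds offer no measurement that would explain this gain.

On these data alone, it remains open whether the gain is specific to fluoro, as chloro or methoxy on the same aromatic carbon would show, and whether trifluoromethyl on that carbon would behave like fluoro or methyl. As far as these compounds go, it is also open whether fluoro on another carbon of the phenyl ring would keep the higher number, and whether the gain would survive a change elsewhere in the shared core.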